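A few compounds are considered here, and "the series" means these few. Any claim that something is new, unique, unknown or untested is made for them only; others in the source may bear on it.

Measured compounds:
Compound 1 `CCOC(=O)C1=Cc2ccccc2OC1(OCc1cn(-c2ccccc2)nn1)C(F)(F)F` — > 150000 nM
Compound 2 `CCOC(=O)C1=Cc2ccccc2OC1(OCc1cc(-c2ccc([N+](=O)[O-])cc2)no1)C(F)(F)F` — > 150000 nM

Compound 1 `CCOC(=O)C1=Cc2ccccc2OC1(OCc1cn(-c2ccccc2)nn1)C(F)(F)F` was tested in a functional assay on A549 cells (Homo sapiens) for inhibition, read by MTT assay, with a stated time of 24 h (on this read-out higher numbers stand for weaker inhibition and lower numbers for stronger inhibition), and for compound 1 the value > 150000 nM is a limit of the assay rather than a number. Compound 2 `CCOC(=O)C1=Cc2ccccc2OC1(OCc1cc(-c2ccc([N+](=O)[O-])cc2)no1)C(F)(F)F` was tested in the same way, and for compound 2 the value > 150000 nM is likewise a limit. Where compound 1 stands is therefore known only as far as the limit of > 150000 nM in this assay, at which 2 of the 2 values shown sit, tells it.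

Compound 3 `CCOC(=O)C1=Cc2ccccc2OC1(OCc1cn(-c2ccc(C)cc2)nn1)C(F)(F)F` has not yet been measured. It differs from compound 1 by methyl in place of hydrogen on an aromatic carbon. Within the data shown here, no step between measured compounds is available to guide the expectation. In this assay the step that the limit leaves unreadable from compound 1 to compound 3 is expected to be none beyond the scatter, because compound 1 already sits at the limit of > 150000 nM in this assay, at which 2 of the 2 values shown sit. Compound 3 is estimated at 200000 nM, within a range from 100000 nM to 500000 nM, and most likely the assay will again report only a limit.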

Compound 3, half-maximal inhibitory concentration: 19700 nM
The estimate for compound 3 lay 10-fold (1.01 log units) above the measured number, outside the stated range (below it).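

In this assay, methyl in place of hydrogen on an aromatic carbon, para to a large group, gives an at least 7.6-fold lower number from compound 1 to compound 3 (0.88 log units; beyond the scatter). Among these compounds, compound 3 is the only one of the three compounds to give a number rather than a limit, so this single change on the phenyl ring is enough to bring the series into the measurable range of this read-out. The step has a lower bound but no upper end, as the value of compound 1 is a limit: the limit of > 150000 nM in this assay, at which 2 of the 3 values shown sit.

The compounds shown leave open whether the step belongs to methyl as such, or would also come with an ethyl chain, a methoxy group or an amine at the same place. They also leave open whether the phenyl to 4-methylphenyl change would have the same effect on any other cell line.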